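Core amino group exchanged for (dimethylamino)methyl

The source may report more compounds than this note shows. Statements on the series, on what has been measured and on what is new or still open speak of the compounds shown alone.

Compound 1 `CNc1nn2c(N)cc(C)nc2c1S(=O)(=O)c1ccccc1` gives 0.302 nM in a functional assay on HEK293 cells for inhibition of 5-hydroxytryptamine receptor 6 (Homo sapiens), read by cAMP accumulation (on this read-out higher numbers stand for weaker inhibition and lower numbers for stronger inhibition), and stands as the higher of the two single numbers recorded so far. Compound 2 `CNc1nn2c(N)cc(C)nc2c1S(=O)(=O)c1cccc(Cl)c1` gives 0.219 nM in this assay, a step of a 1.4-fold lower number from compound 1 to compound 2 (0.14 log units; within the scatter) that concerns only the chloro on the phenyl ring. Compound 3 `CNc1nn2c(N)c(Cl)c(C)nc2c1S(=O)(=O)c1ccccc1` has several entries the several entries of compound 3 in this assay, 0.141 nM; 0.14 nM (2 entries) and gives 0.141 nM; 0.14 nM (2 entries). Compound 4 `CNc1nn2c(CN(C)C)cc(C)nc2c1S(=O)(=O)c1ccccc1` carries (dimethylamino)methyl in place of amino on an aromatic carbon. Among the compounds with values here, no measured step touches this position or this kind of exchange, and the single measured step was within the scatter, so there is no direct guide; a modest weakening is assumed for a change of this size. Compound 4 is therefore expected at 0.8 nM (range 0.2 nM to 4 nM), a step of a 2.6-fold higher number from compound 1 to compound 4 (0.42 log units; beyond the scatter).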

Compound 4, inhibition constant: 1.82 nM
For compound 4 the middle estimate is 2.3-fold (0.36 log units) below the measured one, within the range that was stated.
By their numbers in this assay, from the lowest: compounds 2 and 1 (each within the scatter of the next); then compound 4.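

Putting (dimethylamino)methyl in place of amino on this aromatic carbon gives a 6.0-fold higher number from compound 1 to compound 4 (0.78 log units; beyond the scatter) in this assay. Unlike the chloro exchange on the phenyl ring, this change moves the number beyond the scatter, so the position next to the ring nitrogen is not indifferent to exchange. Nothing measured here explains the step.

On these data alone, whether the step follows from losing amino or from adding (dimethylamino)methyl remains open. Methylamino or aminomethyl at this place would help separate the two.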